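Demethylation of the remaining ester in a glycoside series

The compounds below may be only part of what the source reports. "The series", "measured", "known", "first", "only" and "open" are said of these compounds alone.

Working notes on the series. Compound 1 `C/C=C1/[C@H](O[C@@H]2O[C@H](CO)[C@@H](O)[C@H](O)[C@H]2O)OC=C(C(=O)O)[C@H]1CC(=O)OC` is the reference point of this comparison. In a functional assay on SK-BR-3 cells (Homo sapiens) for antiproliferative activity, read by MTT assay, with a stated time of 72 h (on this read-out higher numbers stand for weaker inhibition and lower numbers for stronger inhibition), compound 1 gives > 20000 nM, which is a limit of the assay rather than a number. Compound 2 `C/C=C1/[C@H](O[C@@H]2O[C@H](CO)[C@@H](O)[C@H](O)[C@H]2O)OC=C(C(=O)OC)[C@H]1CC(=O)OC` carries methyl in place of hydrogen on an oxygen next to a carbonyl group relative to compound 1. In this assay compound 2 gives > 15000 nM, again a limit of the assay and not a number. For the measured compounds named here, the step that the two limits leave unreadable from compound 1 to compound 2 cannot be sized because the limit of > 15000 nM in this assay, at which 1 of the 2 values shown sits, and the limit of > 20000 nM in this assay, at which 1 of the 2 values shown sits, are the only values at its two ends.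

Compound 3 `C/C=C1/[C@H](O[C@@H]2O[C@H](CO)[C@@H](O)[C@H](O)[C@H]2O)OC=C(C(=O)O)[C@H]1CC(=O)O` differs from compound 1 by hydrogen in place of methyl on an oxygen next to a carbonyl group. Going by the values given here, the one measured step, the step from compound 1 to compound 2, concerns the same kind of change in the opposite direction and is unreadable, so no measured step gives a size for this move. Both measured compounds sit at limits, and nothing shown points to measurable inhibition appearing on removal of the methyl. In this assay compound 3 is expected to stay at or beyond the limit, with the step that the limit leaves unreadable from compound 1 to compound 3 expected to be none beyond the scatter. Compound 3 is estimated at 30000 nM, within 10000 nM to 100000 nM.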

Compound 3, half-maximal inhibitory concentration: > 50000 nM
Compound 3 was reported as a limit (the forecaster's own chance of this, stated with the estimate: 90%); middle value at least 1.6-fold (0.22 log units) away from the limit.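

In this assay, compound 1 and compound 3 both stand at limits of the assay, and the step between them cannot be read. The compounds shown leave open whether methoxycarbonyl or carboxy at either place on the shared core makes any difference, since compound 1, compound 2 and compound 3 give no measured number in this assay.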